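The compounds below may be only part of what the source reports. "The series", "measured", "known", "first", "only" and "open" are said of these compounds alone.

Measured so far in an assay on CHO cells for displacement of a labelled ligand from prostaglandin E2 receptor EP3 subtype (Homo sapiens), read by radioligand binding; a higher number here means a weaker inhibitor, a lower number a stronger inhibitor:
compound 1 `CC(C)C(Nc1nccs1)c1ccc(-c2ccc3cccc(F)c3c2)[nH]c1=O` — 9.4 nM
compound 2 `CC(C)C(c1cnc(N)s1)c1ccc(-c2ccc3cccc(F)c3c2)[nH]c1=O` — 16 nM
compound 3 `CC(C)C(c1ncc[nH]1)c1ccc(-c2ccc3cccc(F)c3c2)[nH]c1=O` — 7.3 nM

Compound 3 holds the lowest of the three numbers. Its nearest neighbour is compound 1, with a 1.3-fold lower number from compound 1 to compound 3 (0.11 log units; within the scatter), a step within the scatter; the step of a 2.2-fold lower number from compound 2 to compound 3 (0.34 log units; beyond the scatter) is beyond the scatter, and a 1.7-fold higher number from compound 1 to compound 2 (0.23 log units; within the scatter) again lies within it. Compound 3 and compound 1 are therefore not separated; only compound 2 stands apart.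

Compound 4 `Cc1c[nH]c(C(c2ccc(-c3ccc4cccc(F)c4c3)[nH]c2=O)C(C)C)n1` is the next step from compound 3. The change is methyl in place of hydrogen on an aromatic carbon; it sits on an aromatic carbon of a five-membered aromatic ring with two nitrogen, next to the ring nitrogen, two ring bonds from the ring atom that bears the large group, so that 1H-imidazol-2-yl becomes 4-methyl-1H-imidazol-2-yl.

Among the compounds with values here, none of the measured steps bears on this change: each of them exchanges the whole five-membered ring group, and no pair differs by a methyl on a ring carbon. The three values span only a narrow band, and the exchanges of entire groups moved the number at most modestly. A single methyl is therefore expected to give no step beyond the scatter, with the direction open. Compound 4 is estimated in this assay at 8 nM, range 3 nM to 20 nM, which means an expected step of a 1.1-fold higher number from compound 3 to compound 4 (0.04 log units; within the scatter).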

Compound 4, inhibition constant: 12 nM
Beside the measured number, compound 4's estimate is 1.5-fold (0.18 log units) below it, and the stated range covers the measured number.
By their numbers in this assay, from the lowest: compounds 3, 1, 4 and 2 (each within the scatter of the next, the first and the last beyond it).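

In this assay, within the data shown here, a 1.6-fold higher number from compound 3 to compound 4 (0.22 log units; within the scatter) is the first read of a small addition to the five-membered aromatic ring rather than an exchange of the whole group, and methyl in place of hydrogen on this aromatic carbon gives no step beyond the scatter. Among these compounds, the 4-methyl-1H-imidazol-2-yl group is also not separated from the two other groups, since a 1.3-fold higher number from compound 1 to compound 4 (0.11 log units; within the scatter) and a 1.3-fold lower number from compound 2 to compound 4 (0.12 log units; within the scatter) both lie within the scatter, whereas a 2.2-fold lower number from compound 2 to compound 3 (0.34 log units; beyond the scatter) lies beyond it, so the one separation in the earlier set has no counterpart with the methyl in place. No measurement on hand speaks to the reason for the size of these steps.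

Still open, from the compounds shown here alone, is how a longer chain such as ethyl, an amine or a carboxylic acid would read on the same aromatic carbon of the ring. Open too, going by these compounds, is how a methyl on a ring carbon of the 2-amino-1,3-thiazol-5-yl or (1,3-thiazol-2-yl)amino groups would read.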